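This account rests on a few compounds, and the source may have more. Where it says the series, first, only, none or still open, it means among the compounds named here.

Of the compounds shown here, two carry a number so far. Compound 1 `Cc1ccccc1-n1c(S)nnc1COc1ccc(-c2ccccc2)cc1` gives 56.8% in a functional assay on the whole organism (strain Wistar) for inhibition, with Rattus norvegicus as the target, read by paw edema, with a stated time of 3 h, at a dose of 10 mg/kg by the oral route; on this read-out higher numbers stand for more inhibition at the one dose given (going by the name of the read-out) and lower numbers for less inhibition. Compound 2 `Clc1ccc(Nc2nnc(COc3ccc(-c4ccccc4)cc3)s2)cc1` gives 52.3% in this assay; this is the lower of the two numbers recorded, but the gap to compound 1 lies within the scatter of the read-out, so the two cannot be set apart on the data at hand.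

Compound 3 `Fc1ccc(Nc2nnc(COc3ccc(-c4ccccc4)cc3)s2)cc1` remains unmeasured. It differs from compound 2 in one place: fluoro in place of chloro on an aromatic carbon. Among the measured compounds shown here, no pair of measured compounds differs in this way, so no measured step guides the expectation. With so small an exchange at the same position, no movement beyond the scatter is expected in this assay in either direction.

Compound 3 is therefore estimated at 50% in this assay, with a range of 38% to 62%. The expected step of a number 2.3 percentage points lower from compound 2 to compound 3 (within the scatter) is judged to lie within the usual scatter.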

Compound 3, a percentage reported as inhibition, in the whole organism at one dose (the size of the read-out at that dose, not a potency): 27.3%
Estimate against measurement, compound 3: 22.7 percentage points above; the measured number lies below the stated range.
By their numbers in this assay, from the lowest: compound 3; then compounds 2 and 1 (each within the scatter of the next).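

The 4-chlorophenyl to 4-fluorophenyl exchange is not silent at this position: in this assay the series reads a number 25 percentage points lower from compound 2 to compound 3 (beyond the scatter), so a single halogen atom on the aromatic carbon para to a large group is enough to separate two compounds that otherwise share one structure. The heavy-atom count, the ring count and the hydrogen-bond donor and acceptor counts are the same for compound 2 and compound 3, so these counts do not tell the pair apart. No measurement at hand bears on the origin of this step.

On these data alone, whether a bromo, methyl or methoxy group at this position would read like chloro or like fluoro remains open. With one dose and one time point, the pair also gives no potency and no time course.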